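The compounds below may be only part of what the source reports. "The series", "measured", "known", "first", "only" and "open" are said of these compounds alone.

Compound 2 `O=C(Nc1ccccc1)c1c(O)ccc2cc(-c3cccc(O)c3)ccc12` carries a phenylcarbamoyl group on its shared core. In an in vitro assay on Sf9 cells for inhibition of 17-beta-hydroxysteroid dehydrogenase type 1 (Homo sapiens), tested at 1 uM (on this read-out lower numbers stand for a weaker effect and higher numbers for a stronger effect at the one concentration tested), compound 2 gives 80%, the higher of the two numbers measured here, though the step from its nearest neighbour lies within the scatter. That neighbour is compound 1 `O=C(c1c(O)ccc2cc(-c3cccc(O)c3)ccc12)N1CCCCC1`, which in this assay gives 73%; the change a number 7 percentage points higher from compound 1 to compound 2 (within the scatter) shows that exchanging one amide substituent for another left the read-out essentially unchanged.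

Compound 3 `CNC(=O)CCc1c(O)ccc2cc(-c3cccc(O)c3)ccc12` has not been measured. It differs from compound 2 in one place: 2-(methylcarbamoyl)ethyl in place of phenylcarbamoyl on an aromatic carbon. Among the measured compounds shown here, no measured step covers this kind of change, since the one known step only swaps groups on the carbonyl carbon while keeping the amide attached to the ring. Without a guide, a moderate decrease is expected, giving a number 25 percentage points lower from compound 2 to compound 3 (beyond the scatter). For compound 3 the estimate in this assay is 55%, ranging from 25% to 85%.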

Compound 3, a percentage reported as inhibition, at one concentration (the size of the read-out at that concentration, not a potency): 80%
Compound 3: middle estimate off by 25 percentage points, on the low side; the range from low to high includes it.
By their numbers in this assay, from the lowest: compounds 1, 2 and 3 (each within the scatter of the next).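

In this assay, the step of no change at the digits printed from compound 2 to compound 3 (within the scatter) comes with 2-(methylcarbamoyl)ethyl in place of phenylcarbamoyl on this aromatic carbon, and the step of a number 7 percentage points higher from compound 1 to compound 3 (within the scatter) comes with the same group in place of (piperidin-1-yl)carbonyl. The earlier compounds shown here only varied what sits on a carbonyl attached directly to the ring, whereas compound 3 shows that, at this position, an open chain with no ring and its amide set further out also keeps the read-out within the scatter of both neighbours. Nothing available explains this tolerance.

As far as these compounds go, whether a carboxylic acid or an amine in place of the methylamide end, or a longer chain, would keep the read-out remains open. A percentage at one concentration also leaves open whether compound 2 and compound 3 differ in potency.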